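The compounds below may be only part of what the source reports. "The series", "measured", "known", "first", "only" and "open" are said of these compounds alone.

Three compounds built around a sulfonyl group joined to a quinoline-like core have been measured in an ADME assay on microsomes from liver (Homo sapiens) for metabolic stability, tested at 2.5 uM; on this read-out lower numbers stand for slow clearance and higher numbers for fast clearance. Compound 1 `O=S(=O)(c1cc(F)cc(F)c1)c1cnc2cc(F)ccc2c1-c1ccc(Cl)cc1` gives 0.03 mL/min in this assay. Compound 2 `O=S(=O)(c1cc(Cl)cc(Cl)c1)c1cnc2cc(F)ccc2c1-c1ccc(Cl)cc1` gives 0.13 mL/min in this assay. Compound 3 `O=S(=O)(c1cc(Cl)cc(Cl)c1)c1cnc2c(F)cccc2c1-c1cccc(F)c1` gives 1.08 mL/min in this assay, the highest of the three numbers, with compound 2 nearest to it and compound 1 furthest from it.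

Compounds 2 and 1 differ in a single place: 3,5-difluorophenyl in place of 3,5-dichlorophenyl on a sulfonyl sulfur. That change brought a 4.3-fold lower number from compound 2 to compound 1 (0.64 log units; beyond the scatter). Compounds 2 and 3 both carry the 3,5-dichlorophenyl on the sulfonyl sulfur but differ elsewhere; the difference between the two cores is not broken down here.

Compound 4 `O=S(=O)(c1cc(F)cc(F)c1)c1cnc2c(F)cccc2c1-c1cccc(F)c1` has not yet been measured in this assay. It is related to compound 3 by 3,5-difluorophenyl in place of 3,5-dichlorophenyl on a sulfonyl sulfur, which is the same change that separates compound 2 from compound 1, at the same place. Going by the values given here, only one measured example of this change exists, and the cores of compound 3 and compound 2 differ in ways that are not set out, so the expectation carries real uncertainty. Still, the step from compound 3 to compound 4 is expected to be about a 4.3-fold lower number from compound 3 to compound 4 (0.64 log units; beyond the scatter), because the same change once gave a 4.3-fold lower number from compound 2 to compound 1 (0.64 log units; beyond the scatter). On that basis compound 4 is estimated to give 0.25 mL/min in this assay. The estimate for compound 4 is expected to fall between 0.08 mL/min and 0.7 mL/min.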

Compound 4, intrinsic clearance in a liver preparation (reported as CLH), per the amount of preparation that the assay uses: 1.18 mL/min
Compound 4: the middle estimate sits 4.7-fold (0.67 log units) below what was measured; measured number outside the range, above it.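

In this assay, putting 3,5-difluorophenyl in place of 3,5-dichlorophenyl on the sulfonyl sulfur gave a 1.1-fold higher number from compound 3 to compound 4 (0.04 log units; within the scatter), so on this core the two groups cannot be told apart by this read-out. The same exchange on the core of compound 2 did not behave this way, and the two results differ by more than repeat measurements would explain, which means the size of the step does not carry over as a fixed amount from one core to the other: the same change on two cores in this assay, a 4.3-fold lower number (0.64 log units; beyond the scatter) from compound 2 to compound 1 and a 1.1-fold higher number (0.04 log units; within the scatter) from compound 3 to compound 4, 4.7-fold (0.68 log units) apart, beyond the scatter of two such steps This shows that in these two pairs the outcome of the exchange depends on the core that carries it, but it does not show which feature of the cores matters, and two pairs cannot give a rule for the whole series.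

No single-change pair shown here links the core of compound 2 to the core of compound 3, so it remains open which part of the core sets the difference, and whether a third core would follow either pair. On these data alone, all four compounds carry a halogen-bearing phenyl on the sulfonyl sulfur, so it also remains open how a plain phenyl, a methoxyphenyl or a group carrying an amine in that place would read in this assay.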